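The source may report more compounds than this note shows. Statements on the series, on what has been measured and on what is new or still open speak of the compounds shown alone.

Measured so far:
compound 1 `COc1ccccc1N1CCN(CCCNc2ccncc2C(=O)N(C)C)CC1` gives 50.1 nM;
compound 2 `COc1ccccc1N1CCN(CCCSc2ccccc2C(=O)N(C)C)CC1` gives 12.6 nM;
compound 3 `CN(C)C(=O)c1cccnc1NCCCN1CCN(c2ccccc2C#N)CC1` gives 10 nM.

In a functional assay on aorta for antagonist activity at Alpha-1D adrenergic receptor (Rattus norvegicus) (on this read-out higher numbers stand for weaker binding and lower numbers for tighter binding), compound 3 has the lowest of the three numbers. Compound 2 sits within the scatter of compound 3, so the two cannot be told apart; compound 1 lies beyond the scatter, with a higher number than compound 3. The next compound, compound 4 `CC(C)c1ccccc1N1CCN(CCCNc2ncccc2C(=O)N(C)C)CC1`, keeps the core of compound 3 and differs in one place: isopropyl in place of cyano on an aromatic carbon. Within the data shown here, no measured pair shows this change, so its effect has to be guessed. The step is expected to be small, with the number for compound 4 drifting slightly upward, plausibly staying within the scatter, giving a 2.0-fold higher number from compound 3 to compound 4 (0.30 log units; within the scatter). Compound 4 is therefore expected to land near 20 nM, somewhere between 5 nM and 80 nM in this assay.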

Compound 4, dissociation constant: 63.1 nM
Compound 4: middle estimate off by 3.2-fold (0.50 log units), on the low side, within the range that was stated.
By their numbers in this assay, from the lowest: compounds 3 and 2 (each within the scatter of the next); then compounds 1 and 4 (each within the scatter of the next).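

In this assay, isopropyl in place of cyano on an aromatic carbon, ortho to a large group, gives a 6.3-fold higher number from compound 3 to compound 4 (0.80 log units; beyond the scatter), a step beyond the scatter. Among these compounds, this is the first pair that differs in one place, and it shows that the number responds to the group at this position, rising with this change. Nothing shown accounts for the size of this step.

As far as these compounds go, whether a methyl group, an amine or a carboxylic acid at this carbon would stay close to compound 3 remains open. Also open, from the compounds shown here alone, is whether this change would give a similar step on the core of compound 1 or compound 2.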